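From 2-fluorophenyl to 4-fluorophenyl on compound 2

The source may hold more compounds than are shown below. What is called first, only, known or untested is meant among the compounds shown, and "the series" means these compounds.

For the measured compounds named here, only two compounds have numbers so far in an ADME assay on microsomes from liver (Mus musculus) for metabolic stability, read by LC-MS, with a stated time of 1 h, tested at 5 uM; on this read-out lower numbers stand for a less stable compound and higher numbers for a more stable compound. Compound 1 (`Cc1nc(-c2ccc(F)cc2)c(C(=O)N2CCN(c3cc(Cl)cc(Cl)c3)CC2)o1`) gives 31.1%, and compound 2 (`COc1cc(OC)cc(N2CCN(C(=O)c3oc(C)nc3-c3ccccc3F)CC2)c1`) gives 16.6%. That places compound 2 lowest of the pair, and the gap between the two lies beyond the usual scatter of repeated measurements, so compound 2 is the less stable of them.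

The next compound to be tested is compound 3 (`COc1cc(OC)cc(N2CCN(C(=O)c3oc(C)nc3-c3ccc(F)cc3)CC2)c1`). It is made from compound 2 by one swap: 4-fluorophenyl in place of 2-fluorophenyl on an aromatic carbon. The rest of the molecule stays the same, and the two compounds have the same atoms, joined differently.

Going by the values given here, no two measured compounds differ in just one place, so the data offer no direct guide to what this swap does. With so little to go on, only a small rise is expected, a number 3.4 percentage points higher from compound 2 to compound 3 (within the scatter), and this expected step stays within the scatter. For compound 3 the estimated value is 20%, with an expected range from 8% to 36%.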

Compound 3, percent of the compound remaining: 5.6%
Compound 3: the middle estimate sits 14.4 percentage points above what was measured, and the stated range ends above it.
By their numbers in this assay, from the lowest: compound 3; then compound 2; then compound 1.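

Where the fluorine sits on the phenyl ring matters in this assay: with the 3,5-dimethoxyphenyl group held constant, 4-fluorophenyl in place of 2-fluorophenyl gives a number 11 percentage points lower from compound 2 to compound 3 (beyond the scatter), so these two groups, made of the same atoms, are not interchangeable on this aromatic carbon. A second single-place comparison is now available: with 4-fluorophenyl held constant, 3,5-dimethoxyphenyl in place of 3,5-dichlorophenyl on an amine nitrogen in a ring gives a number 25.5 percentage points lower from compound 1 to compound 3 (beyond the scatter). Both changes lower the number, which leaves compound 3 as the least stable of the three, but nothing measured here says why either step occurs.

From the compounds shown here alone, the 2-fluorophenyl group appears only alongside 3,5-dimethoxyphenyl, so it remains open whether moving the fluorine would have a similar effect alongside 3,5-dichlorophenyl. Going by these compounds, it is also open how other groups on this aromatic carbon, such as a plain phenyl or a 4-chlorophenyl, would compare with the two fluorophenyl groups.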